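From tert-butyl to methyl in a cytotoxicity test

A few compounds are considered here, and "the series" means these few. Any claim that something is new, unique, unknown or untested is made for them only; others in the source may bear on it.

Compound 1 `O=C1[Se]C(=O)c2ccccc21` gives > 100000 nM
Compound 2 `CC(C)(C)C(=O)C[Se]C(=O)c1ccc(Cl)cc1` gives 8100 nM

In an ADME assay on MRC5 cells (Homo sapiens) for cytotoxicity, read by MTT assay, with a stated time of 24 h (a higher number here means a weaker inhibitor, a lower number a stronger inhibitor), compound 1 sits at > 100000 nM and this is a limit of the assay, not a number. Within the data shown here, compound 2 gives 8100 nM and so holds the only actual number so far, which leaves nothing exact to rank it against.

The next compound, compound 3 `CC(=O)C[Se]C(=O)c1ccc(Cl)cc1` has not been measured yet. It carries methyl in place of tert-butyl on a carbonyl carbon and is otherwise the same as compound 2. Among the measured compounds shown here, no two measured compounds differ in just one place, so there is no earlier step to scale this change against.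

In this assay a small step towards a higher number is expected, and it may not clear the usual scatter. The estimate therefore starts from compound 2 at 8100 nM and moves only a little, and the expected step (a 1.4-fold higher number from compound 2 to compound 3 (0.13 log units; within the scatter)) carries wide uncertainty. Compound 3 is expected at 11000 nM with an estimated range of 3500 nM to 35000 nM as its likely span.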

Compound 3, half-maximal inhibitory concentration: 5350 nM
For compound 3 the middle estimate is 2.1-fold (0.31 log units) above the measured one; the measured number falls inside the stated range.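

Among these compounds, this is the first step that can be read in this assay, and it concerns the group on a carbonyl carbon whose other neighbour is a saturated chain carbon. Going from tert-butyl, with 4 heavy atoms, to methyl, with 1 heavy atom, gives a 1.5-fold lower number from compound 2 to compound 3 (0.18 log units; within the scatter), so compound 2 and compound 3 cannot be told apart in this test, even though the group at this position is much smaller in compound 3. Nothing shown here gives a reason for this result.

Among the compounds shown here, one pair covers only one swap at one position, so it remains open whether an amine, a carboxylic acid or a longer chain in the same place would also stay within the scatter of compound 2. On these data alone, compound 1 differs from compound 2 and compound 3 in more than one place and carries only a limit, so no step can be read between it and either of them, and the role of the rest of the structure also remains open.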